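Adding a formyl group to compound 1

The source may hold more compounds than are shown below. What is called first, only, known or untested is meant among the compounds shown, and "the series" means these compounds.

Compound 1 `COc1ccc(-c2cocc2-c2cc(OC)c(OC)c(OC)c2)cc1` gives 39 nM
Compound 2 `COc1ccc(-c2cocc2-c2cc(OC)c(OC)c(OC)c2)cc1[N+](=O)[O-]` gives 245 nM
Compound 3 `COc1ccc(-c2cocc2-c2cc(OC)c(OC)c(OC)c2)cc1N` gives 5.1 nM

In a functional assay on SH-SY5Y cells (Homo sapiens) for cytotoxicity, read by MTT assay (a lower number here means a stronger inhibitor, a higher number a weaker inhibitor), compound 1 holds the middle of these three numbers. Compound 4 `COc1ccc(-c2coc(C=O)c2-c2cc(OC)c(OC)c(OC)c2)cc1` is not yet measured and differs from compound 1 by one change: formyl in place of hydrogen on an aromatic carbon (formyl in place of hydrogen on an aromatic carbon, next to the ring oxygen). Among the measured compounds shown here, two measured steps bear on this. Nitro in place of hydrogen gave a 6.3-fold higher number from compound 1 to compound 2 (0.80 log units; beyond the scatter) and amino in place of hydrogen gave a 7.6-fold lower number from compound 1 to compound 3 (0.88 log units; beyond the scatter) as the opposite move. For the measured compounds named here, both are modest, but neither puts formyl at this place, so they show only that one added group can shift the number modestly. In this assay a modest upward step is expected, estimated as a 2.6-fold higher number from compound 1 to compound 4 (0.41 log units; beyond the scatter) with its direction uncertain. The estimate for compound 4 is 100 nM with 20 nM to 500 nM as its expected range.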

Compound 4, half-maximal inhibitory concentration: 35.8 nM
Beside the measured number, compound 4's estimate is 2.8-fold (0.45 log units) above it; low and high end bracket the measured number.
By their numbers in this assay, from the lowest: compound 3; then compounds 4 and 1 (each within the scatter of the next); then compound 2.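

In this assay, formyl on the aromatic carbon next to the ring oxygen gives a 1.1-fold lower number from compound 1 to compound 4 (0.04 log units; within the scatter). This shows that this place can carry an added group while the two numbers stay within the scatter of each other, whereas the nitro and amino steps, made at a different place, went beyond it. Nothing shown here explains this result. Formyl is the only group shown at this place, so it remains open whether a carboxylic acid or an amine there would behave alike.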